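A few compounds are considered here, and "the series" means these few. Any claim that something is new, unique, unknown or untested is made for them only; others in the source may bear on it.

Measured so far:
compound 1, `O=C(Nc1ccc(Oc2ccnc3[nH]ccc23)cc1)c1cc2cccnc2n(-c2ccc(C(F)(F)F)cc2Cl)c1=O`, 1950 nM in a functional assay on NCI-H460 cells (Homo sapiens) for antiproliferative activity, read by MTT assay, with a stated time of 72 h; a higher number here means a weaker inhibitor, a lower number a stronger inhibitor
compound 2, `COc1ccc(-n2c(=O)c(C(=O)Nc3ccc(Oc4ccnc5c4ccn5C)cc3)cc3cccnc32)cc1`, 1920 nM in this assay

Compound 2 holds the lowest of the two numbers; its nearest neighbour is compound 1, and the two values sit within the scatter of each other, so neither can be called the stronger. Compound 1 and compound 2 differ at two places at once, and no single-point comparison between them is available.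

Compound 3, `Cn1ccc2c(Oc3ccc(NC(=O)c4cc5cccnc5n(-c5ccc(C(F)(F)F)cc5Cl)c4=O)cc3)ccnc21`, is not yet measured. Relative to compound 2 the change is 2-chloro-4-(trifluoromethyl)phenyl in place of 4-methoxyphenyl on an aromatic nitrogen. Among the measured compounds shown here, the same 2-chloro-4-(trifluoromethyl)phenyl group is present in compound 1, and compound 1 and compound 2 give indistinguishable numbers, which is the only guide here. For the measured compounds named here, no step is known for this exchange on a shared core, so the expectation is a step from compound 2 to compound 3 of a 1.0-fold higher number from compound 2 to compound 3 (0.02 log units; within the scatter), no further than the scatter in either direction. Compound 3 is therefore expected to give 2000 nM in this assay, with a range from 700 nM to 6000 nM.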

Compound 3, half-maximal inhibitory concentration: 6950 nM
Compound 3: middle estimate off by 3.5-fold (0.54 log units), on the low side; measured number outside the range, above it.
By their numbers in this assay, from the lowest: compounds 2 and 1 (each within the scatter of the next); then compound 3.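

With methyl on the aromatic nitrogen held fixed in this assay, 2-chloro-4-(trifluoromethyl)phenyl in place of 4-methoxyphenyl on the aromatic nitrogen of the six-membered ring gives a 3.6-fold higher number from compound 2 to compound 3 (0.56 log units; beyond the scatter) and so counts against the larger, halogen-bearing aryl group on this core. With 2-chloro-4-(trifluoromethyl)phenyl held fixed, methyl in place of hydrogen on an aromatic nitrogen gives a 3.6-fold higher number from compound 1 to compound 3 (0.55 log units; beyond the scatter) and so shows that this second site also affects the read-out, a step of similar size to the aryl exchange. The matching numbers of compound 1 and compound 2 therefore do not mean that both sites are indifferent, since each differs from compound 3 by a step beyond the scatter, though no measurement available here bears on the cause of either step.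

Whether the two steps add cannot be judged without the remaining combination, 4-methoxyphenyl with hydrogen on the aromatic nitrogen, which lies outside the compounds shown. Also open, from the compounds shown here alone, is how the aryl site responds to other groups, such as unsubstituted phenyl, 4-chlorophenyl or a phenyl ring bearing an amine, and how the other nitrogen responds to a longer chain such as ethyl.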